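A few compounds are considered here, and "the series" means these few. Any claim that something is new, unique, unknown or untested is made for them only; others in the source may bear on it.

In a functional assay on SMMC-7721 cells (Homo sapiens) for antiproliferative activity, read by MTT assay, with a stated time of 48 h (on this read-out higher numbers stand for weaker inhibition and lower numbers for stronger inhibition), compound 1 `Cn1cc(C2=C(c3nn(CCCN4CCCCC4)c4ncccc34)C(=O)N(c3ccccc3)C2=O)c2ccccc21` gives 3050 nM. Compound 2 `Cn1cc(C2=C(c3nn(CCn4ccnc4)c4ncccc34)C(=O)N(c3ccccc3)C2=O)c2ccccc21` is reported only as a limit, > 100000 nM. Compound 3 `Cn1cc(C2=C(c3nn(CCCn4ccnc4)c4ncccc34)C(=O)NC2=O)c2ccccc21` is also reported only as a limit, > 100000 nM. Compound 2 thus stands at the limit of > 100000 nM in this assay, at which 2 of the 3 values shown sit. Compound 4 `CN(C)CCCn1nc(C2=C(c3cn(C)c4ccccc34)C(=O)N(c3ccccc3)C2=O)c2cccnc21` differs from it by (dimethylamino)methyl in place of 1H-imidazol-1-yl on a saturated chain carbon, two bonds along the chain from an aromatic nitrogen. Within the data shown here, one measured step bears on this change, the large at least 32-fold higher number from compound 1 to compound 2 (1.51 log units; beyond the scatter), where 1H-imidazol-1-yl replaced (piperidin-1-yl)methyl at that place. The entering group is closer in kind to the (piperidin-1-yl)methyl of compound 1, which gives 3050 nM. A large move to a lower number is therefore expected, an at least 20-fold lower number from compound 2 to compound 4 (1.30 log units; beyond the scatter). Compound 4 is estimated at 5000 nM, with an expected range of 1500 nM to 20000 nM.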

Compound 4, half-maximal inhibitory concentration: 31200 nM
The estimate for compound 4 lay 6.2-fold (0.80 log units) below the measured number, outside the stated range (above it).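

Swapping 2-(1H-imidazol-1-yl)ethyl for 3-(dimethylamino)propyl at this place gives a measured number in this assay, with an at least 3.2-fold lower number from compound 2 to compound 4 (0.50 log units; beyond the scatter). Compound 2 is reported only as a limit, so this step is a bound and not a measured size: the limit of > 100000 nM in this assay, at which 2 of the 4 values shown sit.

Among the open-chain and ring amines, the choice also counts, as dimethylamino in place of piperidin-1-yl gives a 10-fold higher number from compound 1 to compound 4 (1.01 log units; beyond the scatter).

The compounds shown leave open whether a pyrrolidine or a morpholine at this place would stand nearer compound 1 or compound 4. They also leave open how a longer chain would read.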